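Swapping methyl for chloro on a low-inhibition sulfonate

The compounds below may be only part of what the source reports. "The series", "measured", "known", "first", "only" and "open" are said of these compounds alone.

Compound 1 `COc1ccc(Cc2nnc(NC(=O)/C(C#N)=C/c3ccccc3OS(=O)(=O)c3ccc(Cl)cc3)s2)cc1` - 34%
Compound 2 `Cc1ccc(S(=O)(=O)Oc2ccccc2/C=C(\C#N)C(=O)Nc2nnc(Cc3ccc(Cl)cc3)s2)cc1` - 20%

In an ADME assay on HEK-293T cells (Homo sapiens) for inhibition, read by CCK-8 assay, with a stated time of 48 h, tested at 20 uM (a lower number here means less inhibition of growth, a higher number more inhibition of growth at the concentration tested), compound 2 stands at 20% and is the lower of the two numbers, while compound 1 reaches 34% and that gap lies beyond the scatter. The next compound, compound 3 `N#C/C(=C\c1ccccc1OS(=O)(=O)c1ccc(Cl)cc1)C(=O)Nc1nnc(Cc2ccc(Cl)cc2)s1`, differs from compound 2 in one place: chloro in place of methyl on an aromatic carbon, which turns 4-methylphenyl into 4-chlorophenyl. Going by the values given here, no measured pair shows this change alone, so the data give no direct size for it. Starting from compound 2 at 20%, with compound 1 at 34% as the only higher number, a small upward move is expected. The estimated step of a number 6 percentage points higher from compound 2 to compound 3 (within the scatter) would stay within the scatter. For compound 3 the expected value is 26%, with an estimated range of 10% to 44%.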

Compound 3, percent growth inhibition at one concentration: 14%
For compound 3 the middle estimate is 12 percentage points above the measured one; the measured number falls inside the stated range.
By their numbers in this assay, from the lowest: compounds 3 and 2 (each within the scatter of the next); then compound 1.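

In this assay, going by these compounds alone, the first direct reading of chloro in place of methyl on an aromatic carbon, para to a large group, gives a number 6 percentage points lower from compound 2 to compound 3 (within the scatter), so the 4-methylphenyl and 4-chlorophenyl versions of this sulfonate cannot be told apart on these numbers. Within the data shown here, the second swap, a methoxy replaced by a chloro, gives a number 20 percentage points lower from compound 1 to compound 3 (beyond the scatter) and is the only one of the two steps that moves the number beyond the scatter. No measurement shown here bears on what lies behind either step.

As far as these compounds go, it remains open how an amine or a carboxylic acid would read at the sulfonyl position held by methyl and chloro. Among these compounds, with only one step for each swap, neither can yet be said to hold on a different partner compound.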